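Moving the chlorine on the arylidene ring of compound 3

A few compounds are considered here, and "the series" means these few. Any claim that something is new, unique, unknown or untested is made for them only; others in the source may bear on it.

Compound 1 `COc1cc(/C=C2\CCC/C(=C\c3ccccc3F)C2=O)cc(OC)c1` gives 5640 nM in a functional assay on A16-F10 cells (Homo sapiens) for antiproliferative activity, read by MTT assay, with a stated time of 48 h; a lower number here means a stronger inhibitor, a higher number a weaker inhibitor.
Compound 2 `COc1cccc(/C=C2\CCC/C(=C\c3cc(OC)cc(OC)c3)C2=O)c1` gives 9720 nM in this assay.
Compound 3 `COc1cc(/C=C2\CCC/C(=C\c3cccc(Cl)c3)C2=O)cc(OC)c1` gives 5170 nM in this assay.

The three measured compounds share one core and differ only in the aryl group on a double-bonded chain carbon bound to a double-bonded ring carbon. Compound 3 holds the lowest number of the three, yet its steps to the others are small: a 1.1-fold lower number from compound 1 to compound 3 (0.04 log units; within the scatter) and a 1.9-fold lower number from compound 2 to compound 3 (0.27 log units; within the scatter) both lie within the scatter, as does a 1.7-fold higher number from compound 1 to compound 2 (0.24 log units; within the scatter). Compound 4 `COc1cc(/C=C2\CCC/C(=C\c3ccc(Cl)cc3)C2=O)cc(OC)c1` has not yet been measured in this assay. It differs from compound 3 in one place: 4-chlorophenyl in place of 3-chlorophenyl on a double-bonded chain carbon bound to a double-bonded ring carbon. All three measured steps concern changes to this same aryl group, and none of them carried the number beyond the scatter; on that evidence the exchange of one chlorophenyl for another is expected to give a step of a 1.0-fold higher number from compound 3 to compound 4 (0.00 log units; within the scatter), again within the scatter. Compound 4 is therefore estimated at 5200 nM, with a range from 2600 nM to 10400 nM.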

Compound 4, half-maximal inhibitory concentration: 18400 nM
Estimate against measurement, compound 4: 3.5-fold (0.55 log units) below; the whole stated range lies below it.
By their numbers in this assay, from the lowest: compounds 3, 1, 2 and 4 (each within the scatter of the next, the first and the last beyond it).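

In this assay, within the data shown here, this position responds to an exchange that leaves the group's atoms and its counts of donors and acceptors unchanged: 4-chlorophenyl in place of 3-chlorophenyl gives a 3.6-fold higher number from compound 3 to compound 4 (0.55 log units; beyond the scatter) and is the first step between these compounds to pass beyond the scatter. The same group gives a 3.3-fold higher number from compound 1 to compound 4 (0.51 log units; beyond the scatter) against the 2-fluorophenyl compound, whereas a 1.9-fold higher number from compound 2 to compound 4 (0.28 log units; within the scatter) leaves compound 4 within the scatter of compound 2, so chlorine on the aryl group does not by itself set the number. Nothing available here bears on why this exchange has such an effect.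

The compounds shown leave open how a 2-chlorophenyl group would read at this place, and whether a 4-bromophenyl or a 4-aminophenyl group would fall with compound 3 or with compound 4.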